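The compounds below may be only part of what the source reports. "The series", "measured", "known", "first", "only" and "open" are said of these compounds alone.

The series shares one core, seen in compound 1 `COc1cc2c(cc1OC)C(CC(=O)O)CC2`, compound 2 `CNC(=O)CC1CCc2cc(OC)c(OC)cc21` and compound 3 `COc1cc2c(cc1OC)C(CC(=O)N1CCCC1)CC2`; the three differ only in the group on a carbonyl carbon. In a functional assay on the whole organism (strain Wistar) for inhibition, with Rattus norvegicus as the target, read by paw edema, with stated times of 60 min and 4 h, at a dose of 100 mg/kg by the oral route (a higher number here means more inhibition at the dose given (going by the name of the read-out), a lower number less inhibition), compound 1 gives 23.9%, compound 2 gives 29.7% and compound 3 gives 24.2%. On the bare numbers compound 3 stands second highest of the three, with compound 1 nearest and compound 2 furthest; the step of a number 0.3 percentage points higher from compound 1 to compound 3 (within the scatter) and the step of a number 5.5 percentage points lower from compound 2 to compound 3 (within the scatter) both lie within the scatter, as does a number 5.8 percentage points higher from compound 1 to compound 2 (within the scatter), so nothing here separates the three.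

Compound 4 `COc1cc2c(cc1OC)C(CC(=O)N1CCCCC1)CC2` is the next member: piperidin-1-yl in place of pyrrolidin-1-yl on a carbonyl carbon. Going by the values given here, the steps that bear on this change are the two already made at the carbonyl carbon, a number 5.5 percentage points lower from compound 2 to compound 3 (within the scatter) and a number 0.3 percentage points higher from compound 1 to compound 3 (within the scatter), neither of which moved the number beyond the scatter. On that ground the expected step is a number 0.2 percentage points lower from compound 3 to compound 4 (within the scatter), that is, no change beyond the scatter in either direction. Compound 4 is therefore estimated at 24% in this assay, with a range from 14% to 34%.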

Compound 4, a percentage reported as inhibition, in the whole organism at one dose (the size of the read-out at that dose, not a potency): 32%
Beside the measured number, compound 4's estimate is 8 percentage points below it; the range from low to high includes it.
By their numbers in this assay, from the lowest: compounds 1, 3, 2 and 4 (each within the scatter of the next).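

In this assay the place on a carbonyl carbon whose other neighbour is a saturated chain carbon now also carries piperidin-1-yl, and the exchange for pyrrolidin-1-yl, one six-membered non-aromatic ring for one five-membered, gives a number 7.8 percentage points higher from compound 3 to compound 4 (within the scatter). Set against the two open-chain or acid ends, the same group gives a number 2.3 percentage points higher from compound 2 to compound 4 (within the scatter) and a number 8.1 percentage points higher from compound 1 to compound 4 (within the scatter), so hydroxy, methylamino, pyrrolidin-1-yl and piperidin-1-yl still stand unseparated at this place, and the ring size of the amide does not yet divide the series. No measurement at hand bears on the reason for any of these steps.

As far as these compounds go, whether any group on this carbonyl carbon can move the number beyond the scatter stays open. Morpholin-4-yl, azepan-1-yl or an unsubstituted amide would test this, and a single oral dose says nothing of how the number follows the dose.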